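Predicting a dimethoxyphenyl analogue in the bile acid receptor assay

The compounds below may be only part of what the source reports. "The series", "measured", "known", "first", "only" and "open" are said of these compounds alone.

Measured compounds:
Compound 1 `COC(=O)/C=C/c1cccc(N(Cc2ccc(-c3ccc(SC)cc3)cc2)C(=O)C(C)C)c1`: 51 nM
Compound 2 `CCOc1cccc(-c2ccc(CN(C(=O)C3CCCCC3)c3cccc(/C=C/C(=O)OC)c3)cc2)c1`: 147 nM
Compound 3 `CCOc1cccc(-c2ccc(CN(C(=O)C(C)C)c3cccc(/C=C/C(=O)OC)c3)cc2)c1`: 173 nM

Of the compounds shown here, three have been measured in an assay on isolated protein with Bile acid receptor (Homo sapiens) as the target; on this read-out lower numbers stand for an effect already at smaller amounts and higher numbers for an effect only at larger amounts of compound. Compound 2 gives the second highest of the three numbers; its nearest neighbour is compound 3, and the pair lies within the scatter a 1.2-fold higher number from compound 2 to compound 3 (0.07 log units; within the scatter). Compound 1 is furthest from compound 2, with a lower number beyond the scatter.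

Compound 4 `COC(=O)/C=C/c1cccc(N(Cc2ccc(-c3c(OC)cccc3OC)cc2)C(=O)C2CCCCC2)c1` has not been measured. It differs from compound 2 in one place: 2,6-dimethoxyphenyl in place of 3-ethoxyphenyl on an aromatic carbon.

Going by the values given here, only one measured step changes the same aromatic group, the one from compound 1 to compound 3 a 3.4-fold higher number from compound 1 to compound 3 (0.53 log units; beyond the scatter), and it was modest. Among the compounds with values here, no measured step shows what two methoxy groups on that ring do. The step from compound 2 to compound 4 in this assay is therefore expected to be small, most likely a somewhat higher number, a 1.7-fold higher number from compound 2 to compound 4 (0.23 log units; within the scatter), with wide uncertainty. Compound 4 is estimated to give 250 nM, in a range from 80 nM to 800 nM.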

Compound 4, half-maximal effective concentration: 77 nM
Estimate against measurement, compound 4: 3.2-fold (0.51 log units) above; the whole stated range lies above it.
By their numbers in this assay, from the lowest: compounds 1, 4, 2 and 3 (each within the scatter of the next, the first and the last beyond it).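

Replacing 3-ethoxyphenyl with 2,6-dimethoxyphenyl on an aromatic carbon, para to a large group, gives in this assay a 1.9-fold lower number from compound 2 to compound 4 (0.28 log units; within the scatter) and leaves the two compounds indistinguishable. Going by these compounds alone, the only earlier change at this position, a 3.4-fold higher number from compound 1 to compound 3 (0.53 log units; beyond the scatter), involved different groups and had isopropyl on the carbonyl, so it said nothing about methoxy groups; here, with cyclohexyl on the carbonyl, the ring carries two methoxy groups in place of one ethoxy group with no change beyond the scatter. No measurement shown explains this result.

Still open, from the compounds shown here alone, is whether a ring with a single methoxy group would read the same, and whether the 2,6-dimethoxyphenyl group would do so with isopropyl on the carbonyl. Going by these compounds, the effect of an amine or a carboxylic acid on this ring also remains unknown.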